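Exchanging 3-Methoxyphenyl for 3-Chloro-5-fluorophenyl

The source may hold more compounds than are shown below. What is called first, only, known or untested is meant among the compounds shown, and "the series" means these compounds.

Compound 1 `Cc1nc(Cc2cccc(C(F)(F)F)c2)sc1-c1ccc(C(N)=O)cc1`: 93%
Compound 2 `Cc1cc(C(N)=O)ccc1-c1sc(Cc2cccc(C(F)(F)F)c2)nc1C`: 87%
Compound 3 `COc1cccc(Cc2nc(C)c(-c3ccc(C(N)=O)c(C)c3)s2)c1`: 85%

All three compounds were tested in a functional assay on cells for agonist activity at G-protein coupled receptor 52 (Homo sapiens), read by AlphaScreen and cAMP accumulation, with a stated time of 30 min; a higher number here means a larger maximal response, a lower number a smaller maximal response. Compound 3 gives the smallest of the three numbers, but its gaps to compound 2 and to compound 1 both lie within the usual scatter. Going by the values given here, the only measured single step, a number 6 percentage points lower from compound 1 to compound 2 (within the scatter), concerns a methyl in place of hydrogen on an aromatic carbon and does not touch the ring changed here. Compound 4 `Cc1cc(-c2sc(Cc3cc(F)cc(Cl)c3)nc2C)ccc1C(N)=O` differs from compound 3 by 3-chloro-5-fluorophenyl in place of 3-methoxyphenyl on a saturated chain carbon bound to an aromatic carbon. Compound 1 carries a different ring at that place and also differs elsewhere, and its value sits within the scatter of compound 3. Among the compounds with values here, no measured step therefore bears directly on this change, and for compound 4 a step of no change at the digits printed from compound 3 to compound 4 (within the scatter) is expected, none beyond the scatter. Compound 4 is estimated at 85%, within 70% to 100%.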

Compound 4, largest response reached (Emax), in percent of the reference or control that the assay uses: 88%
The estimate for compound 4 lay 3 percentage points below the measured number; the range from low to high includes it.
By their numbers in this assay, from the lowest: compounds 3, 2, 4 and 1 (each within the scatter of the next).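

In this assay 3-chloro-5-fluorophenyl can take the place of 3-methoxyphenyl on this saturated chain carbon with no difference that can be told from scatter (a number 3 percentage points higher from compound 3 to compound 4 (within the scatter)). This single pair shows that the maximal response holds up when the ring's oxygen and its one hydrogen-bond acceptor are gone. No measurement shown here accounts for this match.

As far as these compounds go, whether the response would also hold with a ring carrying an amine or a carboxylic acid remains open. A longer chain at this place is equally untested by the compounds shown.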